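Moving the Methoxy Group Around the Terminal Ring

The source may report more compounds than this note shows. Statements on the series, on what has been measured and on what is new or still open speak of the compounds shown alone.

Three ureas built on one shared core have been measured in an assay on isolated protein for inhibition of proto-oncogene tyrosine-protein kinase receptor Ret variant V804L (Homo sapiens), read by 33P incorporation, with stated times of 15 min and 40 min; a higher number here means a weaker inhibitor, a lower number a stronger inhibitor. Compound 1 `O=C(Nc1ccc(Cl)cc1)Nc1ccc(Nc2ncnc3c2OCCN3)cc1` gives > 10000 nM, which is a limit of the assay rather than a number (the limit of > 10000 nM in this assay, at which 1 of the 3 values shown sits). Compound 2 `O=C(Nc1ccc(Nc2ncnc3c2OCCN3)cc1)Nc1ccc(C(F)(F)F)cc1` gives 2470 nM. Compound 3 `COc1ccc(NC(=O)Nc2ccc(Nc3ncnc4c3OCCN4)cc2)cc1` gives 1220 nM, the lowest of the two numbers, with the step of a 2.0-fold lower number from compound 2 to compound 3 (0.31 log units; beyond the scatter) setting it apart from compound 2; the steps of an at least 4.0-fold lower number from compound 1 to compound 2 (0.60 log units; beyond the scatter) and an at least 8.1-fold lower number from compound 1 to compound 3 (0.91 log units; beyond the scatter) likewise exchange one group for another on the terminal ring. Compound 4 `COc1cccc(NC(=O)Nc2ccc(Nc3ncnc4c3OCCN4)cc2)c1` differs from compound 3 by 3-methoxyphenyl in place of 4-methoxyphenyl on an amide-type nitrogen. Among the measured compounds shown here, no measured step moves a group around that ring, so none bears directly on this change; the expected step is therefore within the scatter: a 1.3-fold higher number from compound 3 to compound 4 (0.12 log units; within the scatter). Compound 4 is estimated at 1600 nM, ranging from 500 nM to 5000 nM.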

Compound 4, half-maximal inhibitory concentration: > 10000 nM
Compound 4: no number, only a limit; the forecaster's own chance of this, stated with the estimate: 5%; at least 6.2-fold (0.79 log units) between middle value and limit.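

The placement of the methoxy on the terminal ring matters in this assay: with the same atoms joined differently, 3-methoxyphenyl in place of 4-methoxyphenyl gives an at least 8.1-fold higher number from compound 3 to compound 4 (0.91 log units; beyond the scatter). Methoxy alone therefore does not secure activity, since 3-methoxyphenyl in place of 4-(trifluoromethyl)phenyl gives an at least 4.0-fold higher number from compound 2 to compound 4 (0.60 log units; beyond the scatter). The result for compound 4 is a limit, not a number, and its step with compound 1 cannot be read: the limit of > 10000 nM in this assay, at which 2 of the 4 values shown sit.

As far as these compounds go, it remains open whether this loss is specific to methoxy, or whether an amine or a carboxylic acid in its place on the 3-methoxyphenyl ring would fare likewise.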